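Trimming the amide nitrogen of a weak cold-receptor agonist

The source may report more compounds than this note shows. Statements on the series, on what has been measured and on what is new or still open speak of the compounds shown alone.

The series centres on compound 1 `Cc1ccc(OCC(=O)N(Cc2cccs2)C2CCCCC2)cc1`, whose activity was determined in an assay on HEK293 cells for agonist activity at transient receptor potential cation channel subfamily M member 8 (Homo sapiens), read by fluorescence and calcium flux, with a stated time of 15 min; on this read-out higher numbers stand for an effect only at larger amounts of compound and lower numbers for an effect already at smaller amounts. In this assay, within the data shown here, compound 1 gives 40000 nM, and it is the only compound of the pair with a numerical result. The companion compound 2 `CCN(Cc1cccs1)C(=O)C[C@@H](O)c1ccccc1` was also examined; in this assay compound 2 is recorded as "not active" (no number reported), without a number to set against it. Compound 1 thus stands alone as the single reference point on the scale.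

The proposed compound 3 `Cc1ccc(OCC(=O)N(C)Cc2cccs2)cc1` keeps the core of compound 1 and differs from it by a single substitution: methyl in place of cyclohexyl on an amide-type nitrogen.

Among the measured compounds shown here, no measured pair separated by this change is available, so the size of the step cannot be read from the data. Compound 2, the only other entry, offers no number and so gives no scale for comparison. Taking compound 1 as the anchor, the step from a 2.3-fold higher number from compound 1 to compound 3 (0.35 log units; beyond the scatter) is expected to be modest and to point toward an effect only at larger amounts, but a result within the scatter is also possible. For compound 3 the estimated value is 90000 nM, with an expected range from 25000 nM to 350000 nM, and there is a real chance that this assay returns no number at all for compound 3.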

Compound 3, half-maximal effective concentration: 400 nM
The estimate for compound 3 lay 230-fold (2.35 log units) above the measured number; measured number outside the range, below it.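

In this assay, the amide-type nitrogen whose other neighbours are the carbonyl carbon and a saturated chain carbon proves to be a highly sensitive position: methyl in place of cyclohexyl gives a 100-fold lower number from compound 1 to compound 3 (2.00 log units; beyond the scatter), well beyond the scatter. The earlier compounds shown here, one number and one entry without a number, could not show that this position affects the read-out at all, nor that the smaller group, one carbon against a ring of six, gives the effect at far smaller amounts. Both groups carry no hydrogen-bond donors or acceptors and no net charge, and nothing shown here explains why the number falls so far.

As far as these compounds go, whether the amide hydrogen, a propyl chain or a cyclopropyl ring on this nitrogen would give a number nearer that of compound 3 or that of compound 1 remains open, so the shape of the trend is unknown from this single step. From the compounds shown here alone, it also remains open whether the same swap would have a step of this size on a core other than that of compound 1.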